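Replacing 3-bromophenyl with 2,5-dimethylphenyl on a sulfonamide nitrogen

The compounds below may be only part of what the source reports. "The series", "measured", "known", "first", "only" and "open" are said of these compounds alone.

In a functional assay (CEM-VLB cells, Homo sapiens) for antiproliferative activity, read by sulforhodamine B assay, with a stated time of 48 h (a higher number here means a weaker inhibitor, a lower number a stronger inhibitor), compound 3 `O=C1NCCN1c1ccc(S(=O)(=O)Nc2cccc(Br)c2)cc1` gives 250 nM. That value lies within the scatter of compound 2 `CCc1cccc(NS(=O)(=O)c2ccc(N3CCNC3=O)cc2)c1` at 450 nM, so these two cannot be ranked. Set against compound 3, compound 1 `O=C1NCCN1c1ccc(S(=O)(=O)Nc2ccc3[nH]ccc3c2)cc1` stands clearly apart, with a much higher number of 4840 nM, which marks it as a far weaker inhibitor.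

Compound 4 `Cc1ccc(C)c(NS(=O)(=O)c2ccc(N3CCNC3=O)cc2)c1` has not yet been measured in this assay. It keeps the shared core and differs at one place: 2,5-dimethylphenyl in place of 3-bromophenyl on a sulfonamide nitrogen. Put simply, 2,5-dimethylphenyl stands in place of 3-bromophenyl on a sulfonamide nitrogen.

Among the compounds with values here, one measured step bears directly on this change, bromo in place of ethyl on an aromatic carbon: a 1.8-fold lower number from compound 2 to compound 3 (0.26 log units; within the scatter). That step is small, and it suggests that exchanging a bromo for a carbon group need not move the number much. The high value of compound 1 at 4840 nM shows, however, that compounds differing in this part can lie far apart. Within the data shown here, no measured compound carries a 2,5-dimethylphenyl group, so the range has to stay wide.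

The expected change is a 1.4-fold higher number from compound 3 to compound 4 (0.15 log units; within the scatter), which means no step beyond the scatter is anticipated. For compound 4 the estimate is 350 nM, with an expected range from 120 nM to 1000 nM.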

Compound 4, half-maximal inhibitory concentration: 120 nM
The estimate for compound 4 lay 2.9-fold (0.46 log units) above the measured number, within the range that was stated.
By their numbers in this assay, from the lowest: compound 4; then compounds 3 and 2 (each within the scatter of the next); then compound 1.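

In this assay, putting 2,5-dimethylphenyl in place of 3-bromophenyl on the sulfonamide nitrogen gives a 2.1-fold lower number from compound 3 to compound 4 (0.32 log units; beyond the scatter), and this modest step lies beyond the usual scatter. Set against the 3-ethylphenyl group, the same 2,5-dimethylphenyl group gives a 3.8-fold lower number from compound 2 to compound 4 (0.57 log units; beyond the scatter), so this position can separate these closely related phenyl groups, even though compound 2 and compound 3 themselves could not be ranked. Nothing shown here gives a measured reason for the lower number of compound 4.

The compounds shown do not tell whether both methyl groups are needed, or whether one methyl group on the phenyl ring would give a similar number. They also leave open how the number would move with a larger alkyl group, such as isopropyl, or with a methoxy group, an amine or a carboxylic acid on that ring.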